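From Allyloxy to Pyridin-2-yl: an Expected Step in Stability

This account rests on a few compounds, and the source may have more. Where it says the series, first, only, none or still open, it means among the compounds named here.

Compound 1 `C=CCOc1cc(F)cc(C(=O)NNS(=O)(=O)c2ccccc2F)c1` was tested in an ADME assay on microsomes from liver (Mus musculus) for metabolic stability, read by HPLC, using NADPH, with a stated time of 60 min, tested at 1 uM, in the presence of a further agent that is not named here (on this read-out lower numbers stand for a shorter-lived compound and higher numbers for a longer-lived compound), where it gives 0.0333 h, a very short-lived reading. Compound 3 `Cc1cc(C(=O)NNS(=O)(=O)c2ccccc2F)cc(-n2cc(F)cn2)c1` gives 0.0667 h in this assay, and the gap between compound 3 and compound 1 lies within the usual scatter, so the two cannot be told apart. Compound 2 `C=CCOc1cc(C)c(F)c(C(=O)NNS(=O)(=O)c2ccccc2)c1` returns < 0.0334 h, which is a limit of the assay rather than a number. Compound 1 thus sits among uniformly short-lived compounds in this assay.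

Compound 4 `O=C(NNS(=O)(=O)c1ccccc1F)c1cc(F)cc(-c2ccccn2)c1` has not yet been measured in this assay. It differs from compound 1 in one place: pyridin-2-yl in place of allyloxy on an aromatic carbon. Among the compounds with values here, no measured pair follows the same change, so the expected size of the step rests only on the spread of the three readings above, which stay close together. A modest rise is expected, only just beyond the scatter. Compound 4 is therefore expected to give 0.08 h, within a range from 0.033 h to 0.2 h. That estimate would mean a step of a 2.4-fold higher number from compound 1 to compound 4 (0.38 log units; beyond the scatter).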

Compound 4, half-life: 0.217 h
Beside the measured number, compound 4's estimate is 2.7-fold (0.43 log units) below it; measured number above the stated range.
By their numbers in this assay, from the lowest: compounds 1 and 3 (each within the scatter of the next); then compound 4.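

In this assay, pyridin-2-yl in place of allyloxy on this aromatic carbon gives a 6.5-fold higher number from compound 1 to compound 4 (0.81 log units; beyond the scatter). This position therefore responds to the group it carries, which the closely grouped earlier readings could not show. The step also starts from a reading at the very bottom of what the assay reports, so its size should be read with care: the limit of < 0.0334 h in this assay, at which 1 of the 4 values shown sits.

Going by these compounds, what stays open is which part of the change matters: the loss of the allyloxy chain with its double bond, the arrival of an aromatic ring, or the nitrogen in that ring. A phenyl ring on the same carbon would set the ring against its nitrogen, and a methoxy group would show what a shorter chain without a double bond does.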